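Isoxazole-linked benzothiazole amines: weak antiproliferative series

The compounds below may be only part of what the source reports. "The series", "measured", "known", "first", "only" and "open" are said of these compounds alone.

Two members of this series have been measured in a functional assay on COLO 205 cells (Homo sapiens) for antiproliferative activity, read by MTT assay; on this read-out lower numbers stand for stronger inhibition and higher numbers for weaker inhibition. Compound 1 `COc1ccc2nc(N(Cc3cc(-c4cc(OC)c(OC)c(OC)c4)no3)c3nc4ccc(F)cc4s3)sc2c1` gives 11800 nM in this assay. Compound 2 `FC(F)(F)Sc1ccc(-c2cc(CN(c3ncccn3)c3nc4ccccc4s3)on2)cc1` gives 10100 nM in this assay. Among the compounds with values here, compound 2 therefore holds the lowest of the two numbers so far, but its nearest neighbour is compound 1, and the gap between them lies within the usual scatter, so neither can be called the more active of the pair; both sit in the same weak range.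

Compound 3 `COc1ccc(-c2cc(CN(c3ncccn3)c3nc4ccccc4s3)on2)cc1` is the next analogue to be measured. It differs from compound 2 in one place: methoxy in place of (trifluoromethyl)sulfanyl on an aromatic carbon. Within the data shown here, no step between measured compounds addresses this kind of exchange, so there is nothing to set its size or direction. With both measured compounds in the same weak range, the step from compound 2 to compound 3 is expected to stay within the scatter, with no change beyond it, and the estimated step is a 1.2-fold higher number from compound 2 to compound 3 (0.07 log units; within the scatter). Compound 3 is expected to give about 12000 nM in this assay, with a range from 4000 nM to 40000 nM.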

Compound 3, half-maximal inhibitory concentration: 5040 nM
For compound 3 the middle estimate is 2.4-fold (0.38 log units) above the measured one, within the range that was stated.
By their numbers in this assay, from the lowest: compounds 3, 2 and 1 (each within the scatter of the next, the first and the last beyond it).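

In this assay, within the data shown here, the exchange of 4-((trifluoromethyl)sulfanyl)phenyl for 4-methoxyphenyl gives a 2.0-fold lower number from compound 2 to compound 3 (0.30 log units; within the scatter) and is the first single-place step that can be read. The step lies within the scatter, so this pair does not separate the two groups, although methoxy has 2 heavy atoms where (trifluoromethyl)sulfanyl has 5 and the two share the same place, on an aromatic carbon of a six-membered aromatic ring of carbon only, para to a large group. No supporting measurement bears on this result.

The compounds shown leave open whether an amine, a carboxylic acid or a longer alkoxy chain at this same carbon would move the number beyond the scatter. They also leave open whether the same exchange of methoxy for (trifluoromethyl)sulfanyl would give a step of similar size on the core of compound 1.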